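Enantiomer swap in the thiourea series

This account rests on a few compounds, and the source may have more. Where it says the series, first, only, none or still open, it means among the compounds named here.

Working notes on agonist efficacy. In a functional assay on Right cardiac atrium for agonist activity at histamine H2 receptor (Cavia porcellus), with a stated time of 30 min, in the presence of a further agent that is not named here (on this read-out higher numbers stand for larger maximal responses and lower numbers for smaller maximal responses), compound 1 `COc1ccc(C(C)NC(=O)/N=C(\N)NCCCc2sc(N)nc2C)cc1` gives 0.91. Compound 2 `Cc1nc(N)sc1CCCN/C(N)=N/C(=O)NCc1ccco1` gives 0.58 in this assay. Compound 3 `Cc1nc(N)sc1CCCN/C(N)=N/C(=S)N[C@@H](C)c1ccccc1` gives 0.65 in this assay; its reading is not separated from that of compound 2 beyond the scatter, while compound 1 stands above it beyond the scatter.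

Compound 4 `Cc1nc(N)sc1CCCN/C(N)=N/C(=S)N[C@H](C)c1ccccc1` differs from compound 3 only as follows: the two compounds have the same atoms and bonds and differ only in configuration as drawn: 1 of 2 stereo elements differ; a stereocentre at a saturated chain carbon is drawn S in compound 3 and R in compound 4. Going by the values given here, no measured pair in the set shares this kind of change, so the step is read as open. As a working assumption for compound 4 in this assay, the expected step a number 0.030 lower from compound 3 to compound 4 (within the scatter) is small and not beyond the scatter in either direction. Compound 4 is therefore expected to give 0.62, within a range of 0.45 to 0.8.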

Compound 4, intrinsic activity: the largest response reached, as a fraction of the reference agonist's: 0.87
Estimate against measurement, compound 4: 0.25 below; measured number outside the range, above it.
By their numbers in this assay, from the lowest: compounds 2 and 3 (each within the scatter of the next); then compounds 4 and 1 (each within the scatter of the next).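

In this assay, the configuration at the saturated chain carbon alone shifts the maximal response (a number 0.22 higher from compound 3 to compound 4 (beyond the scatter)). Going by these compounds alone, the stereocentre is therefore not a silent feature of the thiourea series, which the earlier compounds could not show, as none of them formed a pair differing in one place. The step can be assigned to this stereocentre because nothing else separates the pair: the fact that compounds 3 and 4 differ only in the configuration as drawn

From the compounds shown here alone, whether the R configuration also gives the higher response with a carbonyl in place of the thiocarbonyl remains open. So does the outcome with an ethyl group on this stereocentre.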